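The source may hold more compounds than are shown below. What is called first, only, known or untested is meant among the compounds shown, and "the series" means these compounds.

Among the compounds with values here, compound 2 `COc1ccc(Cc2ccc(-c3csc(N)n3)cc2)cc1` stands lowest of the two numbers so far: in an assay on cells for activation of leukotriene A-4 hydrolase (Homo sapiens), with a stated time of 10 min (a higher number here means that more compound is needed for the effect, a lower number that less compound is needed), compound 2 gives 210 nM, while compound 1 `Nc1nc(-c2ccc(Cc3ccc(C(F)(F)F)cc3)cc2)cs1` gives 1390 nM. Within the data shown here, the only measured step, a 6.6-fold lower number from compound 1 to compound 2 (0.82 log units; beyond the scatter), concerns a different exchange at the same aromatic carbon. Compound 3 `Cc1ccc(Cc2ccc(-c3csc(N)n3)cc2)cc1` differs from compound 2 by methyl in place of methoxy on an aromatic carbon. Among the measured compounds shown here, no measured step bears directly on this exchange, so only a modest movement, at most a small rise, is expected, a 1.7-fold higher number from compound 2 to compound 3 (0.22 log units; within the scatter). Compound 3 is therefore estimated at 350 nM in this assay, within a range from 120 nM to 1000 nM.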

Compound 3, concentration for half-maximal activity: 83 nM
Compound 3: middle estimate off by 4.2-fold (0.62 log units), on the high side, and the stated range ends above it.
By their numbers in this assay, from the lowest: compound 3; then compound 2; then compound 1.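

At this position, on an aromatic carbon para to a large group, methyl gives the lowest number of the three in this assay, with a 2.5-fold lower number from compound 2 to compound 3 (0.40 log units; beyond the scatter) and a 17-fold lower number from compound 1 to compound 3 (1.22 log units; beyond the scatter). The order here thus runs methyl, methoxy, trifluoromethyl, and taking away the oxygen of methoxy lowers the number instead of raising it. No measurement shown accounts for this order. As far as these compounds go, whether an ethyl group, a chlorine atom or an amine at this position would give a lower number remains open, as does whether the order holds on a changed core.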